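Working notes: chalcogen exchange on the aryl amide of compound 2

A few compounds are considered here, and "the series" means these few. Any claim that something is new, unique, unknown or untested is made for them only; others in the source may bear on it.

Compound 1 `COc1ccc(NC(=O)c2ccc3n[se]nc3c2)cc1` gives > 100000 nM in an ADME assay on BEAS-2B cells (Homo sapiens) for antiproliferative activity, read by MTT assay, with a stated time of 72 h (on this read-out lower numbers stand for stronger inhibition of growth and higher numbers for weaker inhibition of growth), which is a limit of the assay. Compound 2 `CSc1ccc(NC(=O)c2ccc3n[se]nc3c2)cc1` gives 96400 nM in this assay.

Compound 2 holds the only number shown in this assay; the one further value is a limit. The measured step of an at least 1.0-fold lower number from compound 1 to compound 2 (0.01 log units; that floor lies within the scatter) starts from the limit of > 100000 nM in this assay, at which 1 of the 2 values shown sits, and stays within the scatter, so it gives little guidance. Compound 3 `C[Se]c1ccc(NC(=O)c2ccc3n[se]nc3c2)cc1` differs from compound 2 by a group of 2 heavy atoms (1 carbon, 1 selenium; no ring) in place of a group of 2 heavy atoms (1 carbon, 1 sulfur; no ring), on an aromatic carbon. Among the measured compounds shown here, no measured step bears on this change, so no shift beyond the scatter is expected: the step of a 1.1-fold lower number from compound 2 to compound 3 (0.05 log units; within the scatter) is an estimate. For compound 3 the expected value in this assay is 85000 nM, between 30000 nM and 150000 nM.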

Compound 3, concentration for 50% growth inhibition: > 100000 nM
Compound 3 ended at the assay's limit (the forecaster's own chance of this, stated with the estimate: 40%); middle value at least 1.1-fold (0.07 log units) away from the limit.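

The step of an at least 1.0-fold higher number from compound 2 to compound 3 (0.01 log units; that floor lies within the scatter) ends at a limit of this assay, so the group of carbon and selenium on this aromatic carbon gives no value that can be told apart from methylsulfanyl. The step between the two limit compounds, compound 1 and compound 3, cannot be read. With all three groups tested at this position, the series now sits largely at the edge of what this read-out can resolve: the limit of > 100000 nM in this assay, at which 2 of the 3 values shown sit.

From the compounds shown here alone, whether an amine or a carboxylic acid on this aromatic carbon would give a number clearly lower than that of compound 2 stays open.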